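Methoxy in Place of Fluoro on Compound 3

A few compounds are considered here, and "the series" means these few. Any claim that something is new, unique, unknown or untested is made for them only; others in the source may bear on it.

Three measured compounds share one nucleotide core. Compound 1 `O=c1c2cccnc2ccn1[C@@H]1O[C@H](COP(=O)(O)OP(=O)(O)OP(=O)(O)O)[C@@H](O)[C@H]1O` gives 35 nM in a functional assay for agonist activity at P2Y purinoceptor 2 (Homo sapiens), read by FLIPR; on this read-out lower numbers stand for an effect already at smaller amounts and higher numbers for an effect only at larger amounts of compound. Compound 2 `O=c1c2ccc(F)cc2ccn1[C@@H]1O[C@H](COP(=O)(O)OP(=O)(O)OP(=O)(O)O)[C@@H](O)[C@H]1O` gives 77 nM in this assay, and compound 3 `O=c1c2cc(F)c(F)cc2ccn1[C@@H]1O[C@H](COP(=O)(O)OP(=O)(O)OP(=O)(O)O)[C@@H](O)[C@H]1O` gives 16 nM in this assay. Within the data shown here, compound 3 therefore stands at the lowest of the three numbers; its gap to compound 1 and its gap to compound 2 both lie beyond the scatter, and the only single-point step among the three, a 4.8-fold lower number from compound 2 to compound 3 (0.68 log units; beyond the scatter), is the addition of a fluoro group.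

Compound 4 `COc1cc2ccn([C@@H]3O[C@H](COP(=O)(O)OP(=O)(O)OP(=O)(O)O)[C@@H](O)[C@H]3O)c(=O)c2cc1F` is reached from compound 3 by methoxy in place of fluoro on an aromatic carbon. Among the measured compounds shown here, no measured step exchanges a fluoro for a methoxy, so the one step on record, a 4.8-fold lower number from compound 2 to compound 3 (0.68 log units; beyond the scatter), bears on it only in that it shows a substituent at this aromatic carbon went with a lower number in this assay. Whether a methoxy, with its two heavy atoms and one hydrogen-bond acceptor, keeps that result is not told by the data. The account therefore expects a small step, a 1.9-fold higher number from compound 3 to compound 4 (0.27 log units; within the scatter), not clearly beyond the scatter, in this assay. Compound 4 is estimated at 30 nM, within a range from 10 nM to 90 nM.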

Compound 4, half-maximal effective concentration: 6 nM
Beside the measured number, compound 4's estimate is 5.0-fold (0.70 log units) above it; the whole stated range lies above it.
By their numbers in this assay, from the lowest: compound 4; then compound 3; then compound 1; then compound 2.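

In this assay methoxy in place of fluoro gives a 2.7-fold lower number from compound 3 to compound 4 (0.43 log units; beyond the scatter) and leaves compound 4 with the lowest number of the four compounds. Among these compounds, the fluoro that leaves is the one compound 2 already carries, while the fluoro kept in compound 4 is the one added on the way to compound 3, so this is the first reading of a change at this carbon. It shows that this carbon, ortho to a fluoro group, takes a methoxy with its 2 heavy atoms and 1 hydrogen-bond acceptor and that the number still falls beyond the scatter; nothing at hand accounts for this result.

The compounds shown leave open whether an ethoxy, a hydroxyl or an amine at this carbon would go with a still lower number or a higher one. They also leave open whether the methoxy would keep its result with hydrogen in place of the remaining fluoro, since every comparison here rests on a single step.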